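A few compounds are considered here, and "the series" means these few. Any claim that something is new, unique, unknown or untested is made for them only; others in the source may bear on it.

Compound 1 `COc1ccc(-c2nc3cccc(-c4cc(OC)c(OC)c(OC)c4)c3o2)cc1`: 2200 nM
Compound 2 `COc1cccc(-c2nc3cccc(-c4cc(OC)c(OC)c(OC)c4)c3o2)c1`: 3500 nM
Compound 3 `COc1ccc(-c2nc3cccc(-c4cc(OC)c(OC)c(OC)c4)c3o2)cc1F`: 1800 nM

These values come from a functional assay on A549 cells (Homo sapiens) for antiproliferative activity, read by MTT assay, with a stated time of 48 h; a lower number here means a stronger inhibitor, a higher number a weaker inhibitor. Compound 3, at 1800 nM, lies within the scatter of both other compounds, as shown by a 1.2-fold lower number from compound 1 to compound 3 (0.09 log units; within the scatter) and a 1.9-fold lower number from compound 2 to compound 3 (0.29 log units; within the scatter).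

Compound 4 `COc1cc(-c2cccc3nc(-c4cccc(F)c4)oc23)cc(OC)c1OC` differs from compound 3 by hydrogen in place of methoxy on an aromatic carbon. Hydrogen stands in place of methoxy on an aromatic carbon, ortho to a fluoro group and para to a large group, which turns 3-fluoro-4-methoxyphenyl into 3-fluorophenyl.

Among the compounds with values here, no measured step removes a methoxy group outright, so the evidence is indirect. Changes on this same ring have stayed small: a 1.6-fold higher number from compound 1 to compound 2 (0.20 log units; within the scatter) for 3-methoxyphenyl in place of 4-methoxyphenyl, and a 1.2-fold lower number from compound 1 to compound 3 (0.09 log units; within the scatter) for fluoro in place of hydrogen. In this assay, a similarly small change is therefore expected, with nothing beyond the scatter.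

The expected change is a 1.4-fold higher number from compound 3 to compound 4 (0.14 log units; within the scatter).

The estimated value for compound 4 is 2500 nM, with an expected range from 1000 nM to 7000 nM.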

Compound 4, half-maximal inhibitory concentration: 2600 nM
Estimate against measurement, compound 4: 1.0-fold (0.02 log units) below; measured number inside the range.
By their numbers in this assay, from the lowest: compounds 3, 1, 4 and 2 (each within the scatter of the next).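

In this assay, within the data shown here, the step from 3-fluoro-4-methoxyphenyl to 3-fluorophenyl (a 1.4-fold higher number from compound 3 to compound 4 (0.16 log units; within the scatter)) is the first to remove a methoxy group outright, and it stays within the scatter. Fluoro in place of methoxy (a 1.3-fold lower number from compound 2 to compound 4 (0.13 log units; within the scatter)) and 3-fluorophenyl in place of 4-methoxyphenyl (a 1.2-fold higher number from compound 1 to compound 4 (0.07 log units; within the scatter)) also stay within the scatter, so across these four compounds a methoxy group on this ring is not required for activity at this level. Nothing available here accounts for how little these changes move the number. As far as these compounds go, whether an amine or a carboxylic acid on this ring would give a step beyond the scatter remains open. From the compounds shown here alone, the rest of the molecule is the same in all four compounds, so what it contributes also remains open.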